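The source may hold more compounds than are shown below. What is called first, only, known or untested is meant among the compounds shown, and "the series" means these compounds.

Measured compounds:
- compound 1 `Cc1ccc(C2=NN(c3ccc(S(C)(=O)=O)cc3)C(=O)CC2)cc1`, 46.7%
- compound 2 `CS(=O)(=O)c1ccc(N2N=C(c3ccc(Cl)cc3)CCC2=O)cc1`, 26.6%
- compound 3 `CS(=O)(=O)c1ccc(N2N=C(c3ccc(Cl)c(Cl)c3)CCC2=O)cc1`, 26.6%

These values come from a functional assay on the whole organism (strain Wistar) for inhibition, with Rattus norvegicus as the target, read by paw edema, with stated times of 30 min and 3 h, at a dose of 0.05 mmol/kg by the oral route; on this read-out lower numbers stand for less inhibition and higher numbers for more inhibition at the one dose given (going by the name of the read-out). Compound 3 stands level with compound 2 and together they give the lowest two of the three numbers, as no change at the digits printed from compound 2 to compound 3 (within the scatter) shows; compound 1 sits well higher, as a number 20.1 percentage points lower from compound 1 to compound 3 (beyond the scatter) shows. Compound 4 `Cc1ccc(O)c(C2=NN(c3ccc(S(C)(=O)=O)cc3)C(=O)CC2)c1` differs from compound 3 as follows: 2-hydroxy-5-methylphenyl in place of 3,4-dichlorophenyl on a carbon with a double bond to nitrogen. Among the measured compounds shown here, the steps that bear on this are a number 20.1 percentage points lower from compound 1 to compound 3 (beyond the scatter) and a number 20.1 percentage points lower from compound 1 to compound 2 (beyond the scatter), since both swap a methyl-bearing phenyl for a chlorine-bearing one and both lost inhibition; the reverse move here is expected to regain part of that. For the measured compounds named here, the hydroxyl has no precedent among the measured compounds, so the expectation is uncertain. Compound 4 is therefore expected to give 40%, within 20% to 60%, which is an expected step of a number 13.4 percentage points higher from compound 3 to compound 4 (beyond the scatter).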

Compound 4, a percentage reported as inhibition, in the whole organism at one dose (the size of the read-out at that dose, not a potency): 66.6%
The estimate for compound 4 lay 26.6 percentage points below the measured number; measured number outside the range, above it.
By their numbers in this assay, from the lowest: compounds 2 and 3 (each within the scatter of the next); then compound 1; then compound 4.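

In this assay the 2-hydroxy-5-methylphenyl group gives the highest number of the four compounds, with a number 40 percentage points higher from compound 3 to compound 4 (beyond the scatter) and a number 40 percentage points higher from compound 2 to compound 4 (beyond the scatter) as well as a number 19.9 percentage points higher from compound 1 to compound 4 (beyond the scatter) on the same carbon of the ring. The earlier compounds shown here showed only a fall on going from the methyl-bearing to the chlorine-bearing rings, whereas this change shows that the position can also carry a group that exceeds compound 1. Nothing available explains this rise.

Going by these compounds, compound 4 differs from compound 1 in both the added hydroxyl and the place of the methyl, so the share of each stays open. The 2-hydroxyphenyl and 2-methoxy-5-methylphenyl groups would separate these two parts of the change.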